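Carbamate tail variation on the shared core

This account rests on a few compounds, and the source may have more. Where it says the series, first, only, none or still open, it means among the compounds named here.

Compound 1 `C[C@@H]1CN(C(=O)c2nc(Nc3cc(C4CC4)[nH]n3)c3cc(Cl)ccc3n2)CCN1C(=O)OCc1ccccc1` and compound 2 `CCCCCOC(=O)N1CCN(C(=O)c2nc(Nc3cc(C4CC4)[nH]n3)c3cc(Cl)ccc3n2)C[C@H]1C` share the core and differ only at the carbamate tail. In an assay for inhibition of serine/threonine-protein kinase PAK 4 (Homo sapiens), read by FRET and Z'-LYTE, with a stated time of 60 min, tested at 5 uM, in the presence of a further agent that is not named here (on this read-out lower numbers stand for a weaker effect and higher numbers for a stronger effect at the one concentration tested), compound 1 gives 74%, while compound 2 gives 12.6%. Among the compounds with values here, the one measured step, a number 61.4 percentage points lower from compound 1 to compound 2 (beyond the scatter), shows that the tail is not a silent position. On the numbers shown, compound 2 stands lowest of the two, with compound 1 as its only neighbour and well beyond the scatter above it.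

Compound 3 `C[C@@H]1CN(C(=O)c2nc(Nc3cc(C4CC4)[nH]n3)c3cc(Cl)ccc3n2)CCN1C(=O)OCOC(=O)C(C)(C)C` keeps the core of compound 2 and changes the tail once more: ((tert-butyl)carbonyl)oxy in place of butyl on a saturated chain carbon bound to an oxygen next to a carbonyl group. Within the data shown here, the only step that bears on this change is the phenyl-to-butyl step, which was large and downward; no measured pair shows an acyloxy group entering at this place, so the direction here rests on a single reference point. Among the measured compounds shown here, the expected outcome for compound 3 in this assay is a modest step upward from compound 2, a number 12.4 percentage points higher from compound 2 to compound 3 (beyond the scatter), with wide uncertainty because compound 2 gives 12.6% and the new group has no measured analogue. The estimate for compound 3 is 25%, within 5% to 55%.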

Compound 3, a percentage reported as inhibition, at one concentration (the size of the read-out at that concentration, not a potency): 24.1%
Compound 3: middle estimate off by 0.9 percentage points, on the high side; measured number inside the range.
By their numbers in this assay, from the lowest: compound 2; then compound 3; then compound 1.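

In this assay, the tail now gives the step of a number 11.5 percentage points higher from compound 2 to compound 3 (beyond the scatter), so two groups without a ring at this place, butyl and ((tert-butyl)carbonyl)oxy, are separated beyond the scatter, and the read-out at this position depends on more than whether phenyl is present. Within the data shown here, the step of a number 49.9 percentage points lower from compound 1 to compound 3 (beyond the scatter) still leaves ((tert-butyl)carbonyl)oxy far short of phenyl, so the order phenyl, then ((tert-butyl)carbonyl)oxy, then butyl on the saturated chain carbon holds across these three compounds, with no compound going against it, though three tails cannot establish a wider trend. No measurement at hand speaks to the reason for this order.

From the compounds shown here alone, it remains open whether an acetoxy group or a methoxy group on the same carbon would stand nearer compound 2 or compound 3, which would separate the contribution of the carbonyl from that of the tert-butyl part. Also open, going by these compounds, is whether cyclohexyl or pyridyl in place of phenyl would hold the level of compound 1, and how a tail ending in a tertiary amine or a carboxylic acid would read.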